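This account rests on a few compounds, and the source may have more. Where it says the series, first, only, none or still open, it means among the compounds named here.

Measured compounds:
compound 1, `CC(C)Oc1nc(N)nc2ncc(-c3ccc(C#N)cc3)nc12`, > 10000 nM
compound 2, `COc1ccc(-c2cnc3nc(N)nc(N4CCN(C(=O)Nc5ccc(C)cc5)CC4)c3n2)cc1OC`, 0.8 nM

Of the compounds shown here, two have been tested in a functional assay on cells (T-cell, Homo sapiens) for inhibition; on this read-out lower numbers stand for stronger inhibition and higher numbers for weaker inhibition. Compound 1 `CC(C)Oc1nc(N)nc2ncc(-c3ccc(C#N)cc3)nc12` gives > 10000 nM; this is a limit of the assay and not a number. Compound 2 `COc1ccc(-c2cnc3nc(N)nc(N4CCN(C(=O)Nc5ccc(C)cc5)CC4)c3n2)cc1OC` gives 0.8 nM in this assay. Among the measured compounds shown here, compound 2 thus holds the only number among the two values, the other value being a limit, as the limit of > 10000 nM in this assay, at which 1 of the 2 values shown sits, records.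

Compound 3 `COc1ccc(-c2cnc3nc(N)nc(N4CCN(c5ccc(C)cc5)CC4)c3n2)cc1OC` has not yet been measured. It differs from compound 2 in one place: 4-methylphenyl in place of (4-methylphenyl)carbamoyl on an amine nitrogen in a ring. The leaving group is the larger one; the entering 4-methylphenyl now sits directly on the amine nitrogen in the ring.

For the measured compounds named here, no step between two measured compounds is available, so the size of this change has to be guessed. In this assay the step from compound 2 to compound 3 is expected to lie beyond the usual scatter, toward weaker inhibition, with the expected step being a 13-fold higher number from compound 2 to compound 3 (1.10 log units; beyond the scatter). Compound 3 is estimated to give 10 nM, within a range from 1.5 nM to 80 nM.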

Compound 3, half-maximal inhibitory concentration: 300 nM
Estimate against measurement, compound 3: 30-fold (1.48 log units) below; measured number above the stated range.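

At this amine nitrogen in a ring, the change brings a 380-fold higher number from compound 2 to compound 3 (2.57 log units; beyond the scatter) in this assay, so (4-methylphenyl)carbamoyl and 4-methylphenyl are far from interchangeable here. Both groups carry the same six-membered aromatic ring of carbon, which means the difference lies in the carbamoyl link that joins this ring to the nitrogen in compound 2, a link that holds a carbonyl and an amide hydrogen. Nothing shown explains why removing this link costs so much inhibition, and the single step cannot separate the part played by the carbonyl from that of the amide nitrogen.

As far as these compounds go, what remains open is how a benzoyl group, which keeps the carbonyl but has no amide hydrogen, or a benzyl group, which keeps a single carbon as the link but has no carbonyl, would behave at this nitrogen. Also open, from the compounds shown here alone, is whether the methyl group on the aromatic ring matters to the strong inhibition of compound 2, which a chlorine atom or a hydrogen in its place would test.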